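Swapping 3,4-difluorophenyl for 4-methylbenzyl on an amide-type nitrogen

A few compounds are considered here, and "the series" means these few. Any claim that something is new, unique, unknown or untested is made for them only; others in the source may bear on it.

Compound 1 `COc1cc(NC(=O)/C=C/c2cccc(OCc3ccccc3)c2)cc(OC)c1OC` gives 8500 nM here
Compound 2 `C=C(Br)C(=O)Nc1cccc(/C=C/C(=O)Nc2cccc3ccccc23)c1` gives 830 nM here
Compound 3 `C=C(Br)C(=O)Nc1cccc(/C=C/C(=O)Nc2ccc(F)c(F)c2)c1` gives 90 nM here

All three numbers come from a functional assay on SEM cells (Homo sapiens) for inhibition, read by MTT assay, with a stated time of 72 h (on this read-out lower numbers stand for stronger inhibition and higher numbers for weaker inhibition), and differ from one another beyond the scatter. Compound 3 has the lowest number of the three, so it inhibits most strongly, with compound 2 higher and compound 1 highest. The next compound to be tested is compound 4 `C=C(Br)C(=O)Nc1cccc(/C=C/C(=O)NCc2ccc(C)cc2)c1` in which 4-methylbenzyl takes the place of 3,4-difluorophenyl on an amide-type nitrogen 4-methylbenzyl in place of 3,4-difluorophenyl on an amide-type nitrogen while the rest of compound 3 stays the same. Among the compounds with values here, no measured pair differs in one place only, so this forecast rests on thin evidence. Compound 3 at 90 nM stands at the low end, and compound 2 at 830 nM shows that a neighbour in this set can sit well above it. A moderate upward move toward weaker inhibition is therefore expected, an estimated step of a 3.9-fold higher number from compound 3 to compound 4 (0.59 log units; beyond the scatter) in this assay that may only just clear the scatter. For compound 4 the estimated value is 350 nM with 90 nM to 1500 nM as the expected range.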

Compound 4, half-maximal inhibitory concentration: 1300 nM
Compound 4: the middle estimate sits 3.7-fold (0.57 log units) below what was measured, and the stated range covers the measured number.
By their numbers in this assay, from the lowest: compound 3; then compounds 2 and 4 (each within the scatter of the next); then compound 1.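

Within the data shown here, compound 3 and compound 4 form the first pair here that differs in one place only, so the group on the amide-type nitrogen can now be judged on its own. In this assay putting 4-methylbenzyl in place of 3,4-difluorophenyl brings a 14-fold higher number from compound 3 to compound 4 (1.16 log units; beyond the scatter) and so a large loss of inhibition. Both groups have the same heavy-atom count, one six-membered aromatic ring of carbon only, and no hydrogen-bond donors or acceptors, so this position responds strongly to a change that leaves those counts untouched. No measurement shown bears on why the number rises.

The step changes the fluorines and the benzyl form of the group together, so the compounds shown cannot say which of the two matters. A plain phenyl or a plain benzyl on the same nitrogen would separate them.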